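The compounds below may be only part of what the source reports. "The series", "measured", "known", "first", "only" and "open" are said of these compounds alone.

Working notes on the series, read in a functional assay on COLO 205 cells (Homo sapiens) for inhibition, read by sulforhodamine B assay, with a stated time of 48 h, tested at 50 uM; a lower number here means less inhibition of growth, a higher number more inhibition of growth at the concentration tested. Compound 1 (`O=C1C(=O)N(CCCCCn2cc(COc3cc(=O)oc4ccccc34)nn2)c2ccc(F)cc21`) gives 56% and compound 2 (`COc1ccc2c(c1)C(=O)C(=O)N2CCCn1cc(COc2cc(=O)oc3ccccc23)nn1`) gives 48%. Compound 2 holds the lower of the two numbers, but the pair lies within the scatter, so these values set no order. Among the compounds with values here, the two compounds differ in more than one place, so no single-change step is available as a guide.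

Compound 3 (`O=C1C(=O)N(CCCn2cc(COc3cc(=O)oc4ccccc34)nn2)c2ccc(Cl)cc21`) is not yet measured. It departs from compound 2 in one place: chloro in place of methoxy on an aromatic carbon, with chloro in place of methoxy on an aromatic carbon. No step beyond the scatter is expected in this assay, and the data give no firm direction. Within the data shown here, the only halogen-bearing reference is compound 1 at 56%, which also differs from compound 2 elsewhere and stays within the scatter of it. A slight upward lean toward that value is all that can be read from the pair.

The estimated change a number 4 percentage points higher from compound 2 to compound 3 (within the scatter) is small and remains within the scatter. For compound 3 the expected growth inhibition is 52%, with an estimated range of 38% to 66%.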

Compound 3, percent growth inhibition at one concentration: 67%
Compound 3: middle estimate off by 15 percentage points, on the low side; the whole stated range lies below it.
By their numbers in this assay, from the lowest: compounds 2 and 1 (each within the scatter of the next); then compound 3.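

In this assay, within the data shown here, chloro in place of methoxy on the aromatic carbon gives a number 19 percentage points higher from compound 2 to compound 3 (beyond the scatter), the only single-change step so far and one that lies beyond the scatter. It shows that this position, meta to a fused ring and para to a fused ring, is not indifferent to the group it carries: the numbers for compound 2 and compound 3 separate with the rest of the structure unchanged, so the step belongs to this one exchange. No measurement at hand accounts for the step, and the counted differences, one heavy atom and one hydrogen-bond acceptor fewer on the chloro side, stand only as a description of the exchange.

A single exchange at this carbon cannot tell whether the higher number goes with chloro itself or with the departure of methoxy; bromo, a nitrile, an amine or plain hydrogen at the same carbon would separate those two readings. Also open, on these data alone, is whether the same exchange gives a step of similar size on a longer chain, since compound 2 and compound 3 share one chain length.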